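Replacing the aryl amide of compound 1 with a cyclohexyl amide

This account rests on a few compounds, and the source may have more. Where it says the series, first, only, none or still open, it means among the compounds named here.

Compound 1 `Cc1ccc(C(=O)Nc2cc(-c3ccccc3)nn2-c2ccccc2)cc1` is an amide whose carbonyl carries a 4-methylphenyl group. In an assay on HEK293 cells for displacement of a labelled ligand from metabotropic glutamate receptor 5 (Rattus norvegicus) (on this read-out higher numbers stand for weaker inhibition and lower numbers for stronger inhibition), compound 1 gives 780 nM. Among the measured compounds shown here, the only other measured compound, compound 2 `COc1cccc(-n2nc(-c3ccccc3)cc2NC(=O)c2ccccc2)c1`, gives 2100 nM in this assay, so compound 1 stands lower of the two, with a gap beyond the usual scatter. Compound 3 `O=C(Nc1cc(-c2ccccc2)nn1-c1ccccc1)C1CCCCC1` differs from compound 1 by one change: cyclohexyl in place of 4-methylphenyl on a carbonyl carbon. For the measured compounds named here, no measured pair shows this change, so the expected step of a 1.9-fold higher number from compound 1 to compound 3 (0.28 log units; within the scatter) is a modest weakening. Compound 3 is expected to give 1500 nM, within 600 nM to 4000 nM.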

Compound 3, inhibition constant: 10100 nM
The estimate for compound 3 lay 6.7-fold (0.83 log units) below the measured number; measured number outside the range, above it.
By their numbers in this assay, from the lowest: compound 1; then compound 2; then compound 3.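

In this assay, among the compounds shown here, the group on this carbonyl carbon matters far more than the earlier compounds could show: cyclohexyl in place of 4-methylphenyl gives a 13-fold higher number from compound 1 to compound 3 (1.11 log units; beyond the scatter). Both groups are six-membered carbon rings without hydrogen-bond donors or acceptors, yet this single pair shows that the aromatic ring gives the much lower number. No available data explain the size of this step. Still open, going by these compounds, is whether a pyridyl ring or a tert-butyl group on this carbonyl carbon would keep the number close to that of compound 1.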